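The source may hold more compounds than are shown below. What is called first, only, known or untested is meant among the compounds shown, and "the series" means these compounds.

Working notes on a short series of hydroxyurea-type and related compounds. The single read-out is a functional assay on HeLa cells (Homo sapiens) for inhibition; a higher number here means a weaker inhibitor, a lower number a stronger inhibitor. Compound 1, `CCC(C)C(NC(=O)NO)C(=O)NC1CCCCC1`, gives in this assay > 100000 nM, which is a limit of the assay and not a number. Compound 2, `CCC(C)C1NC(=O)N(C2CCCC2)C1=O`, gives in this assay > 100000 nM, again a limit. Compound 3, `CCC(C)C(NC(=O)n1nnc2ccccc21)C(=O)NCc1ccccc1`, gives in this assay >= 100000 nM, also a limit. Compound 1 therefore stands among values that are all limits: the limit of > 100000 nM in this assay, at which 2 of the 3 values shown sit, covers compound 1 and compound 2, while the limit of >= 100000 nM in this assay, at which 1 of the 3 values shown sits, covers compound 3. Among the compounds with values here, no step between two measured compounds can be computed, so no measured size of a step exists for this series.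

Compound 4, `CCC(C)C(NC(=O)NO)C(=O)NC1CCCC1`, is not yet measured. It differs from compound 1 in one place: cyclopentyl in place of cyclohexyl on an amide-type nitrogen. Since compound 1 sits at a limit, the expected step that the limit leaves unreadable from compound 1 to compound 4 in this assay is none beyond the scatter, and most likely compound 4 will also return only a limit. Compound 4 is estimated at 150000 nM, with an expected range from 50000 nM to 500000 nM.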

Compound 4, half-maximal inhibitory concentration: > 100000 nM
Compound 4 gave a limit, no number (the forecaster's own chance of this, stated with the estimate: 85%); the middle value does not contradict the limit.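

Compound 1 and compound 4 both sit at a limit, so no step can be read for cyclopentyl in place of cyclohexyl on an amide-type nitrogen: the limit of > 100000 nM in this assay, at which 3 of the 4 values shown sit.
The compounds shown leave open what number, if any, lies behind these limits in this assay and which change to the series would give a readable value.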